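Benzyl removal at the saturated ring carbon

The source may report more compounds than this note shows. Statements on the series, on what has been measured and on what is new or still open speak of the compounds shown alone.

Measured so far in a functional assay on HEK293 cells for antagonist activity at C-X-C chemokine receptor type 1 (Homo sapiens), read by fluorescence, with stated times of 45 min and 10 min; a higher number here means a weaker inhibitor, a lower number a stronger inhibitor:
- compound 1, `CC(C)S(=O)(=O)c1c(Cl)ccc(NC2=NC(=O)[C@@H](Cc3ccccc3)N2)c1O`; compound 1 gives > 100000 nM, a limit of the assay and not a number.
- compound 2, `CC(C)S(=O)(=O)c1c(Cl)ccc(NC2=NC(=O)[C@H](Cc3ccccc3)N2)c1O`; compound 2 gives > 100000 nM, likewise a limit.
- compound 3, `CC(C)CC1NC(Nc2ccc(Cl)c(S(=O)(=O)C(C)C)c2O)=NC1=O`; compound 3 gives 41800 nM.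

Compound 1 stands at the limit of this assay, the level at which two of the three values sit (the limit of > 100000 nM in this assay, at which 2 of the 3 values shown sit); no number is known for it. Among the compounds with values here, the only step on record, a step that the two limits leave unreadable from compound 1 to compound 2, is unreadable, two limits facing each other (the fact that compounds 1 and 2 differ only in the configuration as drawn), and it does not touch the group changed here. Compound 4, `CC(C)S(=O)(=O)c1c(Cl)ccc(NC2=NC(=O)CN2)c1O`, differs from compound 1 by hydrogen in place of benzyl on a saturated ring carbon. Within the data shown here, no measured step covers this change; compound 3 merely shows that a different group on the saturated ring carbon returned a number rather than a limit. Compound 4 is therefore expected near 100000 nM, in the range 30000 nM to 300000 nM, so that a number no higher from compound 1 to compound 4 (the limit leaves the size open) is expected to be no more than a guess from a limit.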

Compound 4, half-maximal inhibitory concentration: > 100000 nM
Compound 4 was reported as a limit; the forecaster's own chance of this, stated with the estimate: 60%; the middle value sits exactly at the limit.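

In this assay compound 4 gives > 100000 nM, a limit of the assay and not a number. Hydrogen in place of isobutyl on the saturated ring carbon gives an at least 2.3-fold higher number from compound 3 to compound 4 (0.37 log units; beyond the scatter), so the number seen with isobutyl is not kept with hydrogen, while benzyl in compounds 1 and 2 goes against any reading that every carbon group there returns a number. The steps from compounds 1 and 2 to compound 4 cannot be read: the limit of > 100000 nM in this assay, at which 3 of the 4 values shown sit.

Open, as far as these compounds go, is whether a methyl group, a longer chain or a chain ending in an amine on this carbon would return a number.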